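The source may report more compounds than this note shows. Statements on the series, on what has been measured and on what is new or still open speak of the compounds shown alone.

In a functional assay on NCI-H460 cells (Homo sapiens) for antiproliferative activity, read by MTT assay, with a stated time of 48 h (a higher number here means a weaker inhibitor, a lower number a stronger inhibitor), compound 1 (`COc1cc(-c2cccc3nc(-c4cccc(Br)c4)oc23)cc(OC)c1OC`) gives 3800 nM. Compound 2 (`COc1cc(-c2cccc3nc(-c4ccc(Cl)cc4)oc23)cc(OC)c1OC`) gives only a limit of the assay, > 25000 nM. This places compound 2 at the limit of > 25000 nM in this assay, at which 1 of the 2 values shown sits. Among the compounds with values here, the one measured step is an at least 6.5-fold higher number from compound 1 to compound 2 (0.81 log units; beyond the scatter). The next change, to compound 3 (`COc1cc(-c2cccc3nc(-c4cccc(C)c4)oc23)cc(OC)c1OC`), is 3-methylphenyl in place of 4-chlorophenyl on an aromatic carbon. Compound 3 thus carries a 3-substituted phenyl, as compound 1 does, so a move back toward a lower number of about the size of an at least 6.5-fold higher number from compound 1 to compound 2 (0.81 log units; beyond the scatter) is expected in this assay. The expected step is an at least 4.1-fold lower number from compound 2 to compound 3 (0.61 log units; beyond the scatter). Compound 3 is estimated at 6000 nM, with an expected range of 1500 nM to 25000 nM.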

Compound 3, half-maximal inhibitory concentration: > 25000 nM
Compound 3 ended at the assay's limit; the forecaster's own chance of this, stated with the estimate: 25%; middle value at least 4.1-fold (0.61 log units) away from the limit.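

Methyl in place of bromo gives an at least 6.5-fold higher number from compound 1 to compound 3 (0.81 log units; beyond the scatter) in this assay and so a 3-substituted phenyl alone does not keep a reading inside the assay's range. Compound 3 gives > 25000 nM as a limit of the assay, and the step from compound 2, also at a limit, cannot be read. Of the three aryl groups on this carbon, only the 3-bromophenyl of compound 1 gives a number: the limit of > 25000 nM in this assay, at which 2 of the 3 values shown sit.

Compound 2 changes both halogen and ring position, so a 4-bromophenyl or 3-chlorophenyl would be needed to separate the two. As far as these compounds go, how a 3-aminophenyl or 3-carboxyphenyl would read here remains open.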